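The compounds below may be only part of what the source reports. "The series", "measured", "known", "first", "only" and "open" are said of these compounds alone.

Three compounds sharing one core differ only in the aryl group on a saturated chain carbon bound to a sulfur. Compound 1 `Brc1cccc(CSc2nnc(-c3ccncc3)n2-c2ccccc2)c1` gives 7040 nM in a functional assay on HepG2 cells (Homo sapiens) for inhibition, read by MTT assay, with a stated time of 48 h; a lower number here means a stronger inhibitor, a higher number a weaker inhibitor. Compound 2 `Clc1ccc(CSc2nnc(-c3ccncc3)n2-c2ccccc2)cc1` gives 16900 nM in this assay, and compound 3 `Fc1ccc(CSc2nnc(-c3ccncc3)n2-c2ccccc2)c(F)c1` gives 10200 nM in this assay. On these three numbers compound 3 stands second highest, with compound 1 nearest and compound 2 furthest, and both of those gaps lie within the scatter of the method. Within the data shown here, the only step beyond the scatter is a 2.4-fold higher number from compound 1 to compound 2 (0.38 log units; beyond the scatter), and it is a modest one.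

Compound 4 `O=[N+]([O-])c1cccc(CSc2nnc(-c3ccncc3)n2-c2ccccc2)c1` is not yet measured. Its change from compound 3 is 3-nitrophenyl in place of 2,4-difluorophenyl on a saturated chain carbon bound to a sulfur. Among the measured compounds shown here, the steps that bear on it are the earlier swaps of the aryl group at that same place: a 1.4-fold higher number from compound 1 to compound 3 (0.16 log units; within the scatter) and a 1.7-fold lower number from compound 2 to compound 3 (0.22 log units; within the scatter), each within the scatter, alongside the modest 2.4-fold higher number from compound 1 to compound 2 (0.38 log units; beyond the scatter). Three different aryl groups at this place moved the number only a little, so a similarly small step, none beyond the scatter, is expected for compound 4 in this assay. For the measured compounds named here, no measured compound carries a nitro group, so the direction is uncertain. The expected step is a 1.1-fold lower number from compound 3 to compound 4 (0.03 log units; within the scatter). Compound 4 is therefore estimated at 9500 nM, with a range from 3500 nM to 26000 nM.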

Compound 4, half-maximal inhibitory concentration: 22000 nM
Compound 4: middle estimate off by 2.3-fold (0.36 log units), on the low side, and the stated range covers the measured number.
By their numbers in this assay, from the lowest: compounds 1, 3, 2 and 4 (each within the scatter of the next, the first and the last beyond it).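

The aryl group at this place has more influence than the first three compounds suggested, since in this assay the swap to 3-nitrophenyl gives a change beyond the scatter (a 2.2-fold higher number from compound 3 to compound 4 (0.33 log units; beyond the scatter)). The widest step in the set comes from one substitution on an aromatic carbon, nitro in place of bromo (a 3.1-fold higher number from compound 1 to compound 4 (0.49 log units; beyond the scatter)), while 3-nitrophenyl and 4-chlorophenyl remain close together (a 1.3-fold higher number from compound 2 to compound 4 (0.11 log units; within the scatter)), so compounds 2 and 4 form a high end of the range that compound 1 does not share, with compound 3 within the scatter of both compound 1 and compound 2. Nothing available explains why the nitro group gives this result.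

Every compound shown carries a substituted phenyl at this place, so it remains open how an amine or a carboxylic acid on that ring, or a longer chain between the ring and the sulfur, would change the number. From the compounds shown here alone, compound 1 gives 7040 nM, the lowest in this small set, and it also remains open whether any group can bring the number well down from there, and whether nitro would behave the same way at another ring position.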